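A few compounds are considered here, and "the series" means these few. Any claim that something is new, unique, unknown or untested is made for them only; others in the source may bear on it.

Of the compounds shown here, two have numbers so far in a functional assay on MX1 cells (Homo sapiens) for antiproliferative activity, with a stated time of 72 h (on this read-out higher numbers stand for an effect only at larger amounts of compound and lower numbers for an effect already at smaller amounts), and no single-place comparison can be drawn between them. Going by the values given here, compound 1 (`Cn1cc(-c2ccccc2Oc2ccccc2)ccc1=O`) gives 4800 nM while compound 2 (`Cc1cc(-c2ccccc2Oc2ccccc2)c[nH]c1=O`) gives 2400 nM and these two values lie within the scatter of each other, so compound 1 stands level with the only other measured compound. Compound 3 (`Cn1cc(-c2ccccc2Oc2ccccc2)cc(N)c1=O`) keeps the core of compound 1 with one change (amino in place of hydrogen on an aromatic carbon), amino in place of hydrogen on an aromatic carbon. Among the compounds with values here, the series holds no measured step for this replacement, or for any other single change, so the expectation rests on little. No shift beyond the scatter is expected, with only a weak and uncertain lean towards a lower number. The estimated move (a 1.6-fold lower number from compound 1 to compound 3 (0.20 log units; within the scatter)) is therefore small and stays within the scatter, although a wide range has to be kept open. In this assay the estimated value for compound 3 is 3000 nM (expected range 800 nM to 10000 nM).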

Compound 3, half-maximal effective concentration: > 5000 nM
Compound 3: a limit, no number (the forecaster's own chance of this, stated with the estimate: 10%); middle value at least 1.6-fold (0.22 log units) away from the limit.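

In this assay compound 3 gives > 5000 nM, which is a limit and not a number. Amino in place of hydrogen on an aromatic carbon, two atoms from the ring nitrogen, now supplies the only single-place step in the series; it reads as an at least 1.0-fold higher number from compound 1 to compound 3 (0.01 log units; that floor lies within the scatter), so the floor of this step stays within the scatter and the replacement shows no move towards a lower number. How far the true value of compound 3 lies past that floor cannot be read, because the read-out stops at the limit: the limit of > 5000 nM in this assay, at which 1 of the 3 values shown sits.

The compounds shown leave open whether this outcome belongs to the amino group itself or would also hold for a hydroxyl, a methoxy or a fluorine on the same aromatic carbon, and whether a methylamino or an acetamide there would give a number rather than a limit. Also open, on these data alone, is whether amino at this place would give the same outcome with a hydrogen on the ring nitrogen in place of the methyl group, the form that compound 2 carries.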